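Acylamino benzothiazole thioacetamides: extending the acyl group

The compounds below may be only part of what the source reports. "The series", "measured", "known", "first", "only" and "open" are said of these compounds alone.

Measured compounds:
compound 1 `O=C(CSc1nc2ccc(NC(=O)CCl)cc2s1)NCc1ccc(Cl)cc1` — 4900 nM
compound 2 `CNC(=O)CSc1nc2ccc(NC(=O)c3ccccc3OC)cc2s1` — 23400 nM
compound 3 `CC(=O)Nc1ccc2nc(SCC(=O)NCc3ccc(Cl)cc3)sc2c1` — 10200 nM

In a functional assay on MCF7 cells (Homo sapiens) for cytotoxicity, read by MTT assay, with a stated time of 48 h (on this read-out lower numbers stand for stronger inhibition and higher numbers for weaker inhibition), compound 3 gives 10200 nM, the second highest of the three numbers. Among the measured compounds shown here, its nearest neighbour is compound 1, and the only single-point step in the set, a 2.1-fold higher number from compound 1 to compound 3 (0.32 log units; beyond the scatter), runs between these two. Compound 2 stands furthest from compound 3, beyond the scatter, with a higher number.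

Compound 4 `COc1ccccc1C(=O)Nc1ccc2nc(SCC(=O)NCc3ccc(Cl)cc3)sc2c1` is not yet measured. It differs from compound 3 in one place: 2-methoxyphenyl in place of methyl on a carbonyl carbon. For the measured compounds named here, no measured step concerns this change, so the step of a 2.1-fold higher number from compound 1 to compound 3 (0.32 log units; beyond the scatter) does not bear on it directly. Compound 2 carries the same ((2-methoxyphenyl)carbonyl)amino group but differs from compound 4 elsewhere, so its value can only hint that this acyl group is compatible with a higher number. The expected step is therefore a modest rise in the number, a 1.4-fold higher number from compound 3 to compound 4 (0.14 log units; within the scatter), with wide uncertainty. Compound 4 is estimated at 14000 nM, between 5000 nM and 40000 nM.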

Compound 4, half-maximal inhibitory concentration: 1100 nM
For compound 4 the middle estimate is 13-fold (1.10 log units) above the measured one; measured number outside the range, below it.
By their numbers in this assay, from the lowest: compound 4; then compound 1; then compound 3; then compound 2.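

In this assay the acyl position proves far more responsive than the earlier step suggested: 2-methoxyphenyl in place of methyl on the carbonyl carbon gives a 9.3-fold lower number from compound 3 to compound 4 (0.97 log units; beyond the scatter) and this exceeds the earlier 2.1-fold higher number from compound 1 to compound 3 (0.32 log units; beyond the scatter) at the same carbonyl. The chloromethyl group is also not needed for a low number, since 2-methoxyphenyl in its place gives a 4.5-fold lower number from compound 1 to compound 4 (0.65 log units; beyond the scatter) in the same assay. With the ((2-methoxyphenyl)carbonyl)amino group held constant, 4-chlorophenyl in place of hydrogen on the saturated chain carbon gives a 21-fold lower number from compound 2 to compound 4 (1.33 log units; beyond the scatter) and so the high number of compound 2 does not count against this acyl group.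

An unsubstituted phenyl or a dimethylaminomethyl group on the same carbonyl carbon would show whether the ring alone carries the step or the methoxy group contributes. No supporting data explain these steps.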